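The compounds below may be only part of what the source reports. "The series", "measured", "known", "first", "only" and "open" are said of these compounds alone.

Two members of this series carry numbers. Compound 1 `Cc1ccc(Oc2c(/C=N\CCCCCOc3cc4oc(=O)cc(C)c4cc3Cl)c(C)nn2C)cc1` in a functional assay on HepG2 cells (Homo sapiens) for antiproliferative activity, read by MTT assay, with a stated time of 72 h (on this read-out higher numbers stand for weaker inhibition and lower numbers for stronger inhibition), gives 10300 nM. Compound 2 `Cc1nn(C)c(Oc2ccc(F)cc2F)c1/C=N\CCCCCCOc1cc2oc(=O)cc(C)c2cc1Cl` is known only as a limit of the assay: in this assay compound 2 gives > 25000 nM. Within the data shown here, what the pair shows so far is the limit of > 25000 nM in this assay, at which 1 of the 2 values shown sits, so compound 2 stands at the edge of what the assay reports, and no step between measured compounds can be drawn from it.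

Compound 3 `Cc1nn(C)c(Oc2ccc(I)cc2)c1/C=N\CCCCCCOc1cc2oc(=O)cc(C)c2cc1Cl` is the next to be tested; compared with compound 2 it carries 4-iodophenyl in place of 2,4-difluorophenyl on an oxygen on an aromatic ring. No measured step covers a change of this kind, so the size and direction of the step in this assay are open; a step no larger than the scatter is the plainest expectation, and a gain in inhibition beyond it would have to be shown rather than assumed. On that basis the value estimated for compound 3 in this assay is 20000 nM, between 5000 nM and 60000 nM. The step expected is an at least 1.2-fold lower number from compound 2 to compound 3 (0.09 log units; that floor lies within the scatter).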

Compound 3, half-maximal inhibitory concentration: 14200 nM
For compound 3 the middle estimate is 1.4-fold (0.15 log units) above the measured one, and the stated range covers the measured number.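

In this assay, compound 3 with 4-iodophenyl on the oxygen gives 14200 nM, a number rather than a limit, so this position now has one reading that can be placed on a scale. The exchange of 2,4-difluorophenyl for 4-iodophenyl gives an at least 1.7-fold lower number from compound 2 to compound 3 (0.24 log units; that floor lies within the scatter), the first step available at this place. Compound 2 is known only as a limit of the assay, so this step has a floor but no fixed size: the limit of > 25000 nM in this assay, at which 1 of the 3 values shown sits.

A single pair cannot separate the entry of iodine from the departure of the two fluorine atoms. Also open, from the compounds shown here alone, is how this assay would read with a 4-chlorophenyl, a 4-aminophenyl or a 4-carboxyphenyl in place of 4-iodophenyl.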